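Removing a Methoxy Group from a Chalcone-Type Pyrazole

The compounds below may be only part of what the source reports. "The series", "measured", "known", "first", "only" and "open" are said of these compounds alone.

Among the measured compounds shown here, the two compounds measured so far share one core, a three-carbon bridge with a carbonyl joining a pyrazole to a benzene ring. Compound 1 `COc1cc(-c2cc(/C=C/C(=O)c3ccc(Cl)c(Cl)c3)[nH]n2)cc(OC)c1OC` carries a 3,4-dichlorophenyl on the carbonyl carbon, and in a functional assay on MOLT-4 cells (Homo sapiens) for cytotoxicity, read by sulforhodamine B assay, with a stated time of 48 h, tested at 0.1 uM (on this read-out lower numbers stand for a stronger effect and higher numbers for a weaker effect at the one concentration tested), compound 1 gives 102%. Compound 2 `COc1ccc(C(=O)/C=C/c2cc(-c3cc(OC)c(OC)c(OC)c3)n[nH]2)cc1OC` carries a 3,4-dimethoxyphenyl at that place instead; in this assay compound 2 gives 98%. For the measured compounds named here, the single measured step, a number 4 percentage points lower from compound 1 to compound 2 (within the scatter), therefore shows no real change, and compound 2 holds the lower of the two numbers only by a margin that falls within the scatter.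

Compound 3 `COc1ccc(C(=O)/C=C/c2cc(-c3cc(OC)c(OC)c(OC)c3)n[nH]2)cc1` is not yet measured. It differs from compound 2 in one place: hydrogen in place of methoxy on an aromatic carbon. Going by the values given here, no measured step concerns the loss of a methoxy group, so the only guide is that swapping the whole group on the carbonyl carbon moved nothing beyond the scatter. On that footing the step of a number 1 percentage points higher from compound 2 to compound 3 (within the scatter) is expected to stay within the scatter. For compound 3 the estimated value in this assay is 99%, with a range from 86% to 110%.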

Compound 3, a percentage reported as activity, at one concentration (the size of the read-out at that concentration, not a potency): 103%
Beside the measured number, compound 3's estimate is 4 percentage points below it, and the stated range covers the measured number.
By their numbers in this assay, from the lowest: compounds 2, 1 and 3 (each within the scatter of the next).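

In this assay, the first measured loss of a methoxy group, turning the 3,4-dimethoxyphenyl into a 4-methoxyphenyl, gives a number 5 percentage points higher from compound 2 to compound 3 (within the scatter) and so does not separate hydrogen from methoxy on this aromatic carbon. The 4-methoxyphenyl is also not separated from the 3,4-dichlorophenyl on the carbonyl carbon, with a number 1 percentage points higher from compound 1 to compound 3 (within the scatter) as the step between them, so all three groups at this place give numbers within the scatter of one another at the single concentration tested. No independent measurement offers an explanation for how closely these numbers sit together.

The compounds shown leave open whether an amine or a carboxylic acid on this ring, or a longer chain such as butoxy in place of methoxy, would give a step beyond the scatter. Also open, on these data alone, is whether a plain phenyl on the carbonyl carbon, with no methoxy group left at all, would stay within the scatter of these three compounds or move clearly away from them.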